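This account rests on a few compounds, and the source may have more. Where it says the series, first, only, none or still open, it means among the compounds named here.

Within the data shown here, in an ADME assay on Raji cells (Homo sapiens) for cytotoxicity, with a stated time of 72 h (on this read-out higher numbers stand for an effect only at larger amounts of compound and lower numbers for an effect already at smaller amounts), compound 3 `Cc1cc(NC(=O)Nc2ccc(SC(F)(F)F)cc2)c2ccccc2n1` gives 10000 nM, the only actual number in the set so far. Compound 1 `CSc1ccc(NC(=O)Nc2cc(C)nc3ccccc23)cc1` reads > 25000 nM, which is a limit of the assay. Compound 2 `Cc1ccc(NC(=O)Nc2cc(C)nc3ccccc23)cc1` reads > 25000 nM, also a limit. The step that the two limits leave unreadable from compound 1 to compound 2 therefore cannot be sized.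

Compound 4 `COc1ccc(NC(=O)Nc2cc(C)nc3ccccc23)cc1` departs from compound 3 by one change, methoxy in place of (trifluoromethyl)sulfanyl on an aromatic carbon, para to a large group.

The measured steps that bear on this change are an at least 2.5-fold lower number from compound 1 to compound 3 (0.39 log units; beyond the scatter) and an at least 2.5-fold lower number from compound 2 to compound 3 (0.39 log units; beyond the scatter). Both lie beyond the scatter, and in both the compound with the (trifluoromethyl)sulfanyl group carries the lower number. The change to compound 4 removes that group, so a move back to a higher number in this assay is expected, of about the same modest size. The expected step is a 2.5-fold higher number from compound 3 to compound 4 (0.40 log units; beyond the scatter). A reading that gives only a limit is quite likely. For compound 4 the estimated value is 25000 nM, with an expected range of 12000 nM to 50000 nM.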

Compound 4, half-maximal effective concentration: > 25000 nM
Compound 4 was reported as a limit; the forecaster's own chance of this, stated with the estimate: 70%; the middle value sits exactly at the limit.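

In this assay, putting methoxy in place of (trifluoromethyl)sulfanyl on the aromatic carbon para to a large group gives an at least 2.5-fold higher number from compound 3 to compound 4 (0.39 log units; beyond the scatter). Of the four groups now shown at this place, only (trifluoromethyl)sulfanyl in compound 3 gives an actual number, while methylsulfanyl in compound 1, methyl in compound 2 and methoxy in compound 4 each give only a limit. The steps among compound 1, compound 2 and compound 4 cannot be read, because all three stand at the same limit: the limit of > 25000 nM in this assay, at which 3 of the 4 values shown sit.

From the compounds shown here alone, how far the true values of compound 1, compound 2 and compound 4 lie past that limit stays unknown, and no order among them can be given. Going by these compounds, whether trifluoromethoxy, an amine or a longer chain at this place would give an actual number also stays open.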